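A few compounds are considered here, and "the series" means these few. Any claim that something is new, unique, unknown or untested is made for them only; others in the source may bear on it.

Compound 1 `Cc1c(C(=O)N/N=C\c2ccncc2)oc2cccc(O)c12`, compound 2 `Cc1c(C(=O)N/N=C\c2c(O)cccc2Cl)oc2cccc(O)c12`, compound 3 `Cc1c(C(=O)N/N=C\c2ccccc2F)oc2cccc(O)c12` and the not yet measured compound 4 `Cc1c(C(=O)N/N=C\c2ccc(F)cc2)oc2cccc(O)c12` share one core and differ only in the group on the carbon with a double bond to nitrogen. In a functional assay on PC-3 cells (Homo sapiens) for inhibition (a higher number here means a weaker inhibitor, a lower number a stronger inhibitor), compound 2 gives 18700 nM. Compound 1 reaches only a limit of the assay, >= 40000 nM. Compound 3 likewise reaches only a limit of the assay, >= 40000 nM. Compound 3 thus stands at the weak end of what the numbers show: the step of an at least 2.1-fold higher number from compound 2 to compound 3 (0.33 log units; beyond the scatter) is at least modest, and the step that the two limits leave unreadable from compound 1 to compound 3 cannot be read because both compounds sit at the limit (the limit of >= 40000 nM in this assay, at which 2 of the 3 values shown sit).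

The change to compound 4 is 4-fluorophenyl in place of 2-fluorophenyl on a carbon with a double bond to nitrogen. For the measured compounds named here, no measured step exchanges one fluorophenyl for another, so the only guide is that compound 3 with 2-fluorophenyl and compound 1 with pyridin-4-yl both sit at the limit, while only compound 2 gives a number. Compound 4 is therefore expected to come out at 40000 nM, in the range 15000 nM to 100000 nM. The expected step of a number no higher from compound 3 to compound 4 (the limit leaves the size open) is none beyond the scatter.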

Compound 4, half-maximal inhibitory concentration: >= 40000 nM
Compound 4: a limit, no number (the forecaster's own chance of this, stated with the estimate: 65%); the middle value lies on the limit itself.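

Moving the fluorine from the 2-fluorophenyl of compound 3 to the 4-fluorophenyl of compound 4 gives no number in this assay, so neither fluorophenyl yields a readable value on this carbon, and the steps among compound 1, compound 3 and compound 4 cannot be read. For the compounds shown here, compound 2, with 2-chloro-6-hydroxyphenyl, remains the only compound here with a number, and the change to 4-fluorophenyl brings an at least 2.1-fold higher number from compound 2 to compound 4 (0.33 log units; beyond the scatter). The series now sits largely at one place: the limit of >= 40000 nM in this assay, at which 3 of the 4 values shown sit.

From the compounds shown here alone, it remains open whether the chlorine or the hydroxyl of compound 2 accounts for its number, which 2-chlorophenyl and 2-hydroxyphenyl on the same carbon would separate. Also open, going by these compounds, is how a 4-hydroxyphenyl or 4-aminophenyl group would read at this position.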